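The source may report more compounds than this note shows. Statements on the series, on what has been measured and on what is new or still open speak of the compounds shown alone.

Among the compounds with values here, in a functional assay on 4T1 cells (Mus musculus) for cytotoxicity, read by MTT assay, with a stated time of 24 h (a higher number here means a weaker inhibitor, a lower number a stronger inhibitor), two compounds carry numbers so far. Compound 1, `COc1ccc(/C=C2\CN(C(=S)SCc3cn(Cc4ccccc4F)nn3)C/C(=C\c3ccc(OC)cc3)C2=O)cc1`, gives 49900 nM, and compound 2, `Cc1ccc(/C=C2\CN(C(=S)SCc3cn(Cc4ccccc4F)nn3)C/C(=C\c3ccc(C)cc3)C2=O)cc1`, gives 28400 nM. These two values lie within the scatter of each other, so compound 1 stands level with compound 2 and the pair cannot be ranked.

Compound 3, `COc1ccc(/C=C2\CN(C(=S)SCc3cn(Cc4cccc(Cl)c4)nn3)C/C(=C\c3ccc(OC)cc3)C2=O)cc1`, has not yet been measured. It keeps the core of compound 1 and differs in one place: 3-chlorophenyl in place of 2-fluorophenyl on a saturated chain carbon bound to an aromatic nitrogen. In words, 3-chlorophenyl stands in place of 2-fluorophenyl on a saturated chain carbon bound to an aromatic nitrogen, which can also be read as 2-fluorobenzyl to 3-chlorobenzyl.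

Within the data shown here, no measured pair isolates a change at this place, so the data offer no step to carry over. Among the measured compounds shown here, the only guide is the starting value of compound 1 at 49900 nM. No step beyond the scatter is expected in this assay, and no direction is favoured. The estimate amounts to an expected step of a 1.2-fold lower number from compound 1 to compound 3 (0.10 log units; within the scatter). For compound 3 the estimated value is 40000 nM, with an expected range from 16000 nM to 80000 nM.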

Compound 3, half-maximal inhibitory concentration: 69700 nM
Compound 3: the middle estimate sits 1.7-fold (0.24 log units) below what was measured; measured number inside the range.
By their numbers in this assay, from the lowest: compounds 2, 1 and 3 (each within the scatter of the next, the first and the last beyond it).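

Within the data shown here, compound 3 gives the first reading of a change at this place, on a saturated chain carbon bound to an aromatic nitrogen, as compounds 1 and 2 differ from each other elsewhere. In this assay, 3-chlorophenyl in place of 2-fluorophenyl gives a 1.4-fold higher number from compound 1 to compound 3 (0.15 log units; within the scatter), so this exchange of 2-fluorobenzyl for 3-chlorobenzyl does not separate the two compounds in this read-out. Nothing available here explains how these two groups compare in this assay.

The exchange alters both the halogen and its place on the ring, so neither alteration can be read alone, and a single pair cannot show whether this place tolerates changes more generally. Still open, going by these compounds, are whether a benzyl group carrying an amine or a carboxylic acid, or a longer chain between the ring and the aromatic nitrogen, would move the number beyond the scatter, and whether the same exchange would read alike on the core of compound 2.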